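Swapping Ethoxy for Chloro on a Shared Core

The source may hold more compounds than are shown below. What is called first, only, known or untested is meant among the compounds shown, and "the series" means these compounds.

Of the compounds shown here, two built on the same core have been measured in an in vitro assay on cells for inhibition of Amine oxidase [flavin-containing] A (Homo sapiens), read by fluorescence and spectrophotometry, with a stated time of 20 min; a lower number here means a stronger inhibitor, a higher number a weaker inhibitor. Compound 1 `Cn1c(=O)c2c(nc(CSc3cccc(Br)c3)n2C)n(C)c1=O` gives 23800 nM, and compound 2 `CCOc1cccc(SCc2nc3c(c(=O)n(C)c(=O)n3C)n2C)c1` gives 44700 nM. Within the data shown here, compound 2 carries the nominally higher of these two numbers, yet its only neighbour, compound 1, lies within the scatter of it, so the two cannot be told apart. Among the measured compounds shown here, the single measured step, a 1.9-fold higher number from compound 1 to compound 2 (0.27 log units; within the scatter), is therefore no real change.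

Compound 3 `Cn1c(=O)c2c(nc(CSc3cccc(Cl)c3)n2C)n(C)c1=O` is the next member: chloro in place of ethoxy on an aromatic carbon. This step bears a close relation to the one already seen, since it removes the ethoxy that the step from compound 1 to compound 2 introduced, and puts a chloro where compound 1 had bromo. Because that step was a 1.9-fold higher number from compound 1 to compound 2 (0.27 log units; within the scatter), the expectation for this assay is a step of similar size in the opposite direction, that is, none beyond the scatter, namely a 1.7-fold lower number from compound 2 to compound 3 (0.24 log units; within the scatter). On that basis compound 3 is estimated at 26000 nM, with a plausible range from 10000 nM to 65000 nM.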

Compound 3, half-maximal inhibitory concentration: 19400 nM
Compound 3: the middle estimate sits 1.3-fold (0.13 log units) above what was measured, and the stated range covers the measured number.
By their numbers in this assay, from the lowest: compounds 3, 1 and 2 (each within the scatter of the next, the first and the last beyond it).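

Among these compounds, at this place on the aromatic ring, replacing ethoxy with chloro gives the first step that lies beyond the scatter (a 2.3-fold lower number from compound 2 to compound 3 (0.36 log units; beyond the scatter)), though it is only a modest one, so in this assay the group here can make a small but readable difference. Chloro and bromo, by contrast, cannot be told apart (a 1.2-fold lower number from compound 1 to compound 3 (0.09 log units; within the scatter)), and since the step between bromo and ethoxy stayed within the scatter, the separation of ethoxy from the halogens rests on the chloro compound alone and is a narrow one. Nothing measured here explains why the chloro and ethoxy compounds differ.

The compounds shown cover only bromo, chloro and ethoxy at this one place, so it remains open how an amine, a carboxylic acid or a longer chain such as butoxy would read there. Also open, going by these compounds, is whether the small gap between chloro and ethoxy would hold if the same groups were placed elsewhere on the aromatic ring or if the shared core were changed.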